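The compounds below may be only part of what the source reports. "The series", "measured", "known", "first", "only" and "open" are said of these compounds alone.

Compound 1 `Cc1cc(-c2ccccc2)n(/C(N)=N/S(=O)(=O)c2cc(C)c(Cl)cc2SCc2cccc(C(F)(F)F)c2)n1`: 19000 nM
Compound 2 `Cc1cc(S(=O)(=O)/N=C(\N)n2nccc2-c2ccccc2)c(SCc2cccc(C(F)(F)F)c2)cc1Cl`: 14000 nM

Of the compounds shown here, two have been measured in a functional assay on HCT-116 cells (Homo sapiens) for cytotoxicity, read by MTT assay, with a stated time of 72 h; on this read-out higher numbers stand for weaker inhibition and lower numbers for stronger inhibition. Compound 1 gives 19000 nM, and compound 2 gives 14000 nM. Compound 1 has the highest of the two numbers; its nearest neighbour is compound 2, with a 1.4-fold lower number from compound 1 to compound 2 (0.13 log units; within the scatter), so the two values cannot be told apart.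

Compound 3 `Cc1cc(-c2ccccc2)n(/C(N)=N/S(=O)(=O)c2cc(C)c(Cl)cc2SCc2ccccc2C(F)(F)F)n1` has not yet been measured. It differs from compound 1 in one place: 2-(trifluoromethyl)phenyl in place of 3-(trifluoromethyl)phenyl on a saturated chain carbon bound to a sulfur. The two compounds share the same atoms, joined differently, so only the position of the trifluoromethyl on the phenyl carried by the saturated chain carbon bound to a sulfur is moved.

Among the compounds with values here, no measured step involves this part of the molecule. Within the data shown here, the only step available, hydrogen in place of methyl on an aromatic carbon from compound 1 to compound 2, lies within the scatter and concerns a different position. There is therefore nothing to point to a change beyond the scatter in this assay for compound 3. Compound 3 is estimated at 19000 nM, with a range of 7000 nM to 50000 nM. This estimate means no change at the digits printed from compound 1 to compound 3 (within the scatter).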

Compound 3, half-maximal inhibitory concentration: 25000 nM
For compound 3 the middle estimate is 1.3-fold (0.12 log units) below the measured one; the measured number falls inside the stated range.
By their numbers in this assay, from the lowest: compounds 2, 1 and 3 (each within the scatter of the next).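

In this assay, the step that moves the trifluoromethyl on the phenyl, with 2-(trifluoromethyl)phenyl in place of 3-(trifluoromethyl)phenyl on a saturated chain carbon bound to a sulfur, reads as a 1.3-fold higher number from compound 1 to compound 3 (0.12 log units; within the scatter) and so leaves the two compounds indistinguishable. Within the data shown here, the earlier compounds touched only a methyl on an aromatic carbon, so this is the first reading at this part of the molecule: with the same atoms joined differently, these two placements of the trifluoromethyl show no difference beyond the scatter. No independent measurement is available that bears on this result.

The compounds shown leave open whether a plain phenyl, or a nitrile or methoxy group in place of the trifluoromethyl, would give a number beyond the scatter from that of compound 1. They also leave open whether a longer chain in place of the saturated chain carbon bound to a sulfur would do so.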